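This account rests on a few compounds, and the source may have more. Where it says the series, first, only, none or still open, it means among the compounds named here.

Of the compounds shown here, three share a core and have been tested in a functional assay on A549 cells (Homo sapiens) for antiproliferative activity, read by MTT assay, with a stated time of 72 h; on this read-out lower numbers stand for stronger inhibition and higher numbers for weaker inhibition. Compound 1 `C=CC(=O)Nc1cc2c(N3CCc4ccccc43)ncnc2cc1OC` gives 5580 nM. Compound 2 `C=CC(=O)Nc1cc2c(N3CCc4ccccc43)ncnc2cc1O[C@@H]1CCOC1` gives 9320 nM, the highest of the three numbers, though its distances to the other two lie within the scatter. Compound 3 `CC/C=C/C(=O)Nc1cc2c(N3CCCc4ccccc43)ncnc2cc1OC` gives 5030 nM. Going by the values given here, the one single-point step among them, a 1.7-fold higher number from compound 1 to compound 2 (0.22 log units; within the scatter), is within the scatter and concerns the group on the ring oxygen, not the part changed here.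

Compound 4 `CN1CCN(C/C=C/C(=O)Nc2cc3c(N4CCc5ccccc54)ncnc3cc2O[C@@H]2CCOC2)CC1` differs from compound 2 in one place: 3-(4-methylpiperazin-1-yl)prop-1-en-1-yl in place of vinyl on a carbonyl carbon. Among the compounds with values here, no measured step covers this kind of change, and compound 3, which carries a different chain on the carbonyl, also differs from compound 1 in its core ring, so its number alone cannot be read as a step. With nothing to point either way, the change from compound 2 to compound 4 is expected to give a 1.3-fold lower number from compound 2 to compound 4 (0.12 log units; within the scatter), a step not beyond the scatter. Compound 4 is therefore estimated at 7000 nM, with a range from 2500 nM to 25000 nM.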

Compound 4, half-maximal inhibitory concentration: 6090 nM
Compound 4: the middle estimate sits 1.1-fold (0.06 log units) above what was measured; low and high end bracket the measured number.
By their numbers in this assay, from the lowest: compounds 3, 1, 4 and 2 (each within the scatter of the next).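

Replacing vinyl with 3-(4-methylpiperazin-1-yl)prop-1-en-1-yl on a carbonyl carbon gives a 1.5-fold lower number from compound 2 to compound 4 (0.18 log units; within the scatter) in this assay, so this swap cannot be told apart from the ordinary spread of repeated measurements. The new point shows that this position, on a carbonyl carbon bonded to an amide-type nitrogen, can carry a group of 10 heavy atoms with a six-membered non-aromatic ring in place of one of 2 heavy atoms, while the two numbers stay within the scatter of each other.

Still open, as far as these compounds go, is how a morpholine ring or a dimethylamino group at the end of the same chain would read, and whether the same swap would read alike with methyl on the ring oxygen. Nothing measured here offers an explanation for this result.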